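The compounds below may be only part of what the source reports. "The series", "measured", "known", "first", "only" and "open" are said of these compounds alone.

Three compounds sharing one core were tested in a functional assay on MGC-803 cells (Homo sapiens) for inhibition, read by MTT assay, with a stated time of 72 h; on this read-out higher numbers stand for weaker inhibition and lower numbers for stronger inhibition. Compound 1 `O=C(CSc1nc(Nc2ccccc2)c2ccccc2n1)Nc1cccc(Br)c1` gives 9620 nM. Compound 2 `O=C(CSc1nc(Nc2ccccc2)c2ccccc2n1)Nc1ccc(Cl)c(Cl)c1` gives 37900 nM, and the change between them reads a 3.9-fold higher number from compound 1 to compound 2 (0.60 log units; beyond the scatter). Compound 3 `C=CC(=O)Nc1cccc(NC(=O)CSc2nc(Nc3cccc(F)c3)c3ccccc3n2)c1` gives 6250 nM, the lowest of the three numbers, within the scatter of compound 1 yet beyond it from compound 2. Compound 4 `C=CC(=O)Nc1cccc(NC(=O)CSc2nc(Nc3ccc(Cl)cc3)c3ccccc3n2)c1` is not yet measured. It differs from compound 3 by 4-chlorophenyl in place of 3-fluorophenyl on a nitrogen on an aromatic ring. Within the data shown here, the one measured step sits on an amide-type nitrogen, not on the nitrogen on an aromatic ring, so no measured step bears on this swap, and no shift beyond the scatter is expected. For compound 4 an inhibitory concentration of 6500 nM is expected, between 2500 nM and 17000 nM. That expectation amounts to a step of a 1.0-fold higher number from compound 3 to compound 4 (0.02 log units; within the scatter), within the scatter.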

Compound 4, half-maximal inhibitory concentration: 14300 nM
Estimate against measurement, compound 4: 2.2-fold (0.34 log units) below; the range from low to high includes it.
By their numbers in this assay, from the lowest: compounds 3, 1 and 4 (each within the scatter of the next, the first and the last beyond it); then compound 2.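

In this assay, among these compounds, this is the first measured change on the nitrogen on an aromatic ring, and it moves the number modestly but beyond the scatter (a 2.3-fold higher number from compound 3 to compound 4 (0.36 log units; beyond the scatter)). The group carried on this nitrogen therefore matters to the read-out, as the group on the amide-type nitrogen already did. No available evidence explains the shift.

The swap changes both the halogen and its place on the ring, so a 3-chlorophenyl or 4-fluorophenyl group would be needed to separate the two. From the compounds shown here alone, how a methoxy group or an amine on this ring would read also remains open.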